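The compounds below may be only part of what the source reports. "The series", "measured", "known", "first", "only" and "open" are said of these compounds alone.

Measured compounds in this series:

Compound 1, `CC[C@H](C)[C@H](NC(=O)c1cccc(Cn2ccnc2)c1)C(=O)NS(=O)(=O)c1ccccc1`, in an assay on HEK293 cells for displacement of a labelled ligand from Type-2 angiotensin II receptor (Homo sapiens), tested at 10 uM (on this read-out lower numbers stand for a weaker effect and higher numbers for a stronger effect at the one concentration tested), gives 24%.
Compound 2, `CC[C@H](C)[C@H](NC(=O)c1cccc(Cn2ccnc2)c1)C(=O)NNS(=O)(=O)c1c(C)cc(C)cc1C`, gives 27%.
Compound 3, `CC[C@H](C)[C@H](NC(=O)c1cccc(Cn2ccnc2)c1)C(N)=O`, gives "not active" (no number reported), and no number was given for it.

Compound 3 therefore stands apart from the other two on the numbers shown: compound 1 and compound 2 each come with a modest read-out, while compound 3 comes with no single number at all, only the statement that nothing was seen. The two numbers for compound 1 and compound 2 lie within the scatter of each other, so nothing separates them.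

The next compound, compound 4, `CCCCNC(=O)[C@@H](NC(=O)c1cccc(Cn2ccnc2)c1)[C@@H](C)CC`, has not yet been measured. It differs from compound 3 in one place: butyl in place of hydrogen on an amide-type nitrogen. For the measured compounds named here, no pair of measured compounds differs in just one place, so there is no measured step to lean on. What compound 1 with its value of 24% and compound 2 with its value of 27% show is that variation in this part of the molecule has so far brought only modest read-outs. The expected step in this assay from compound 3 to compound 4 is small, upward at most, or none beyond the scatter. The estimate for compound 4 is 15%, with a range from 0% to 35%.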

Compound 4, a percentage reported as inhibition, at one concentration (the size of the read-out at that concentration, not a potency): 3%
The estimate for compound 4 lay 12 percentage points above the measured number, and the stated range covers the measured number.
By their numbers in this assay, from the lowest: compound 4; then compounds 1 and 2 (each within the scatter of the next).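

Placing butyl where phenylsulfonyl stood on the amide-type nitrogen gives, in this assay, a number 21 percentage points lower from compound 1 to compound 4 (beyond the scatter), the first single-place change in this series with a readable size. It shows that the read-out at this position depends on which group the nitrogen carries, and that a butyl chain alone does not keep the modest displacement seen with phenylsulfonyl: compound 4 gives only 3% in this assay. The change from hydrogen to butyl cannot be read as a step, as compound 3 has no number, and nothing measured here explains why phenylsulfonyl and butyl differ.

From the compounds shown here alone, it remains open whether the sulfonyl link or the phenyl ring of phenylsulfonyl matters more, a question that a benzyl group, a benzoyl group or a methylsulfonyl group on the same nitrogen could help to answer. A carboxylic acid in place of the terminal amide is also absent from the compounds shown, so its effect on the read-out at this end of the molecule remains unknown.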